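Swapping a pyridine for a phenyl on compound 2

A few compounds are considered here, and "the series" means these few. Any claim that something is new, unique, unknown or untested is made for them only; others in the source may bear on it.

compound 1 `O=C(CN1CCN(c2nnc(Cc3ccccc3)c3ccccc23)CC1)Nc1ccc(Br)cc1`: 12400 nM
compound 2 `O=C(CN1CCN(c2nnc(Cc3ccncc3)c3ccccc23)CC1)Nc1ccc(F)c(Cl)c1`: 4 nM

In a functional assay on MDA-MB-231 cells (Homo sapiens) for cytotoxicity, read by MTT assay, with a stated time of 72 h (on this read-out higher numbers stand for weaker inhibition and lower numbers for stronger inhibition), compound 2 has the lower of the two numbers, 4 nM, well beyond the scatter. Compound 3 `O=C(CN1CCN(c2nnc(Cc3ccccc3)c3ccccc23)CC1)Nc1ccc(F)c(Cl)c1` has not been measured yet. It differs from compound 2 in one place: phenyl in place of pyridin-4-yl on a saturated chain carbon bound to an aromatic carbon. Compound 1 carries that phenyl too and gives 12400 nM, though its structure differs elsewhere as well. In this assay a weaker result is therefore expected, and the estimated 75-fold higher number from compound 2 to compound 3 (1.88 log units; beyond the scatter) lies beyond the scatter. For compound 3 the expected value is 300 nM, with an estimated range of 15 nM to 6000 nM.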

Compound 3, half-maximal inhibitory concentration: 7360 nM
The estimate for compound 3 lay 25-fold (1.39 log units) below the measured number, outside the stated range (above it).
By their numbers in this assay, from the lowest: compound 2; then compounds 3 and 1 (each within the scatter of the next).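

In this assay, changing only pyridin-4-yl to phenyl on a saturated chain carbon bound to an aromatic carbon gives a 1800-fold higher number from compound 2 to compound 3 (3.26 log units; beyond the scatter), so with this amide group, the low number depends on that one ring nitrogen. With phenyl in this place, 3-chloro-4-fluorophenyl in place of 4-bromophenyl on an amide-type nitrogen gives a 1.7-fold lower number from compound 1 to compound 3 (0.23 log units; within the scatter), so that swap does not separate these two compounds. No measurement here explains the effect of the nitrogen. As far as these compounds go, it remains open whether pyridin-3-yl, pyridin-2-yl or pyrimidin-5-yl in this place would keep the low number, and whether pyridin-4-yl would do so alongside 4-bromophenyl.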